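The source may report more compounds than this note shows. Statements on the series, on what has been measured and on what is new or still open speak of the compounds shown alone.

In a functional assay on the whole organism (stomach) for inhibition, with Canis familiaris (Canis lupus familiaris) as the target, at a dose of 5 mg/kg by the intravenous route (on this read-out lower numbers stand for a weaker effect and higher numbers for a stronger effect at the one dose given), compound 2 `Cc1nc2c(OCc3ccccc3)cccn2c1C#N` gives 4%; compound 1 `Cc1nc2c(OCc3ccccc3)cccn2c1C(N)=O` gives 2% in the same test, and compound 3 `COCc1c(C)nc2c(OCc3ccccc3)cccn12` gives 29%. The step of a number 2 percentage points higher from compound 1 to compound 2 (within the scatter) lies within the scatter, so compound 2 sits with compound 1 at the low end of the three numbers and clearly under compound 3. Compound 4 `CSCc1c(C)nc2c(OCc3ccccc3)cccn12` differs from compound 2 by (methylsulfanyl)methyl in place of cyano on an aromatic carbon. The step that bears on this exchange is a number 25 percentage points higher from compound 2 to compound 3 (beyond the scatter), where methoxymethyl replaced cyano on an aromatic carbon, and the parallel step a number 27 percentage points higher from compound 1 to compound 3 (beyond the scatter) points the same way. A comparable rise of roughly a number 21 percentage points higher from compound 2 to compound 4 (beyond the scatter) is therefore expected for compound 4. Compound 4 is estimated at 25%, within a range from 5% to 45%.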

Compound 4, a percentage reported as inhibition, in the whole organism at one dose (the size of the read-out at that dose, not a potency): 8%
For compound 4 the middle estimate is 17 percentage points above the measured one; low and high end bracket the measured number.
By their numbers in this assay, from the lowest: compounds 1, 2 and 4 (each within the scatter of the next); then compound 3.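

In this assay, the oxygen of the chain cannot be exchanged for sulfur without loss: a number 21 percentage points lower from compound 3 to compound 4 (beyond the scatter). Compound 4 stays level with the earlier nitrile and carboxamide, with a number 4 percentage points higher from compound 2 to compound 4 (within the scatter) and a number 6 percentage points higher from compound 1 to compound 4 (within the scatter). A chain on this aromatic carbon therefore does not by itself raise the read-out, and among these four compounds only compound 3 stands apart.

Nothing given here explains the gap between the methoxy and methylsulfanyl chains. From the compounds shown here alone, whether a hydroxymethyl group, an aminomethyl group or a longer ether chain here would follow compound 3 or compound 4 remains open.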